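The compounds below may be only part of what the source reports. "The series", "measured", "known", "first", "only" and "open" are said of these compounds alone.

Measured in a functional assay on T-24 cells (Homo sapiens) for cytotoxicity, read by colorimetric assay and MTT assay; on this read-out higher numbers stand for weaker inhibition and lower numbers for stronger inhibition:
- compound 1 `COc1ccc(-c2cc3c(OC)ccc(OC)c3nc2O)cc1`: 10000 nM
- compound 2 `CCOC(=O)Cn1c(=O)c(-c2ccc(OC)cc2)cc2c(OC)cc(OC)cc21`: 10000 nM
- compound 3 `CCN(CC)C(=O)Cn1c(=O)c(-c2ccc(OC)cc2)cc2c(OC)cc(OC)cc21`: 10000 nM

In this assay the three compounds sit level, and compound 3 reads the same as the other two at 10000 nM. For the measured compounds named here, no measured compound in this small set stands apart from the others.

The next compound to be tested is compound 4 `COc1ccc(-c2cc3c(OC)cc(OC)cc3n(CCCC#N)c2=O)cc1`, which keeps the shared core of compound 3 and changes only the side chain: 2-cyanoethyl in place of diethylcarbamoyl on a saturated chain carbon bound to an aromatic nitrogen. In words, 2-cyanoethyl stands in place of diethylcarbamoyl on a saturated chain carbon bound to an aromatic nitrogen.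

Going by the values given here, only one measured step bears on this side chain. Its end group was exchanged with no change at the digits printed from compound 2 to compound 3 (within the scatter). Among the compounds with values here, that step is small, but it is a single example, and no measured compound carries a nitrile, so the data do not test this group directly. No step beyond the scatter is therefore expected in this assay, in either direction.

The expected outcome is no change at the digits printed from compound 3 to compound 4 (within the scatter). Compound 4 is estimated at 10000 nM, with an expected range from 4500 nM to 20000 nM.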

Compound 4, half-maximal inhibitory concentration: 10000 nM
Compound 4: middle estimate and measured number agree at the digits printed, within the range that was stated.
By their numbers in this assay, from the lowest: compounds 1, 2, 3 and 4 (each within the scatter of the next).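

In this assay, putting 2-cyanoethyl in place of diethylcarbamoyl on a saturated chain carbon bound to an aromatic nitrogen gave no change at the digits printed from compound 3 to compound 4 (within the scatter), and putting it in place of ethoxycarbonyl gave no change at the digits printed from compound 2 to compound 4 (within the scatter). The end of this side chain has now been tried with a nitrile as well as with the ester and the amide, so the chain no longer needs its carbonyl to give the same reading, and the smaller entering group, with 4 heavy atoms against 7 for diethylcarbamoyl, leaves the number where it was. No information is available on why these exchanges leave the reading as it stands.

Since all of the compounds shown read alike, none of them reveals a group at this position that moves the number in either direction, and the position's influence on the reading remains undefined. A primary amine or a carboxylic acid at the end of the chain, a much longer chain, or a hydrogen in place of the whole side chain would each test this position in a way that the ester, the amide and the nitrile do not.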